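Adding a chloro to the shared core of compound 1

A few compounds are considered here, and "the series" means these few. Any claim that something is new, unique, unknown or untested is made for them only; others in the source may bear on it.

Measured so far in a functional assay on OVCAR-3 cells (Homo sapiens) for cytotoxicity, read by sulforhodamine B assay, with a stated time of 48 h; on this read-out higher numbers stand for lower toxicity in this test and lower numbers for higher toxicity in this test:
- compound 1 `ClCc1ccc(Cn2cnc3c(Cl)ncnc32)cc1` gives 8910 nM
- compound 2 `ClCc1cccc(Cn2cnc3ncnc(Cl)c32)c1` gives 43700 nM
- compound 3 `ClCc1ccccc1Cn1cnc2ncnc(Cl)c21` gives 8310 nM

Compound 1 stands second highest of the three numbers; its nearest neighbour is compound 3, within the scatter, and the furthest is compound 2, whose number is higher by a gap beyond the scatter.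

Compound 4 `ClCc1ccc(Cn2cnc3c(Cl)nc(Cl)nc32)cc1` differs from compound 1 by chloro in place of hydrogen on an aromatic carbon, on the carbon between two ring nitrogen atoms. Among the compounds with values here, no measured pair shows this kind of change, so nothing here fixes its size. The step from compound 1 to compound 4 in this assay is expected to be small, likely within the scatter, if anything toward a lower number: a 1.5-fold lower number from compound 1 to compound 4 (0.17 log units; within the scatter). Compound 4 is therefore estimated at 6000 nM, with a range from 2000 nM to 20000 nM.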

Compound 4, concentration lethal to 50% of the cells: 9550 nM
Compound 4: the middle estimate sits 1.6-fold (0.20 log units) below what was measured; the measured number falls inside the stated range.
By their numbers in this assay, from the lowest: compounds 3, 1 and 4 (each within the scatter of the next); then compound 2.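

In this assay, within the data shown here, chloro in place of hydrogen on the aromatic carbon between two ring nitrogen atoms gives a 1.1-fold higher number from compound 1 to compound 4 (0.03 log units; within the scatter), the first single-place step. On compound 1, this carbon therefore carries a chloro without a shift beyond the scatter. Nothing available explains this result.

As far as these compounds go, whether an amine or a methoxy group on this carbon would give a similarly small step remains open. So does whether the same chloro change on compound 2 or compound 3 would give a step of like size.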